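The source may hold more compounds than are shown below. What is called first, only, known or untested is meant among the compounds shown, and "the series" means these compounds.

Compound 1 `CNC(=O)c1sc(N2CC3CC2(CNC(=O)c2c[nH]c4ncccc24)C3)nc1C(F)(F)F` gives 200 mL.min-1.g-1 in an ADME assay on microsomes from liver (Homo sapiens) for metabolic stability; a higher number here means faster removal of the compound, a lower number slower removal.
Compound 2 `CNc1nc(OC2CCCC2)nc2c1ncn2Cc1c(F)cccc1F` gives 240 mL.min-1.g-1 in this assay.
Compound 3 `CNC(=O)c1sc(N2CC3CC2(CNC(=O)c2c[nH]c4ncc(C)cc24)C3)nc1C(F)(F)F` gives only a limit, > 270 mL.min-1.g-1, in this assay.

Of the two numbers shown in this assay, the gap between compound 2 and compound 1 lies within the usual scatter; compound 3 stands at a limit of the assay, (the limit of > 270 mL.min-1.g-1 in this assay, at which 1 of the 3 values shown sits). Within the data shown here, the one measured step, an at least 1.3-fold higher number from compound 1 to compound 3 (0.13 log units; that floor lies within the scatter), concerns methyl in place of hydrogen on an aromatic carbon within a different core, so it tells nothing about the change leading to compound 4 `CNc1nc(OCC2CCC2)nc2c1ncn2Cc1c(F)cccc1F`, which is cyclobutylmethyl in place of cyclopentyl on an oxygen on an aromatic ring. Among the measured compounds shown here, with no measured step bearing on this change, the expectation is no movement beyond the scatter, an estimated no change at the digits printed from compound 2 to compound 4 (within the scatter). Compound 4 is therefore expected at 240 mL.min-1.g-1, in a range from 130 mL.min-1.g-1 to 400 mL.min-1.g-1.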

Compound 4, intrinsic clearance in microsomes in the Homo sapiens assay: > 270 mL.min-1.g-1
Compound 4 ended at the assay's limit (the forecaster's own chance of this, stated with the estimate: 35%); middle value at least 1.1-fold (0.05 log units) away from the limit.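

The only step shown at this position, cyclopentyl to cyclobutylmethyl, reads in the Homo sapiens assay as an at least 1.1-fold higher number from compound 2 to compound 4 (0.05 log units; that floor lies within the scatter). The value of compound 4 is a limit of the assay and not a number: the limit of > 270 mL.min-1.g-1 in the Homo sapiens assay, at which 2 of the 4 values shown sit.

In a physicochemical assay for lipophilicity, at pH 7.4 (on this read-out lower numbers stand for lower lipophilicity and higher numbers for higher lipophilicity), compound 2 gives 4.3 and compound 4 gives 4.4, a gap within the usual scatter.

On these data alone, how far compound 4 really lies from compound 2 stays open. So does whether an amine or a carboxylic acid on the cyclobutylmethyl group would give a lower number in the Homo sapiens assay.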